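Swapping the sulfonamide for a toluamide on the linker

The source may report more compounds than this note shows. Statements on the series, on what has been measured and on what is new or still open speak of the compounds shown alone.

Measured so far:
compound 1, `O=S(=O)(NCCNc1nccc(-c2c(-c3cccc(F)c3)nc3sccn23)n1)c1ccc(Cl)cc1`: 18600 nM
compound 2, `O=S(=O)(NCCNc1nccc(-c2c(-c3cccc(F)c3)nc3sccn23)n1)c1ccccc1`: 11000 nM

In a functional assay on A-375 cells (Homo sapiens) for cytotoxicity, read by MTT assay (on this read-out higher numbers stand for weaker inhibition and lower numbers for stronger inhibition), compound 2 gives 11000 nM, and compound 1 gives 18600 nM; the step of a 1.7-fold lower number from compound 1 to compound 2 (0.23 log units; within the scatter) lies within the scatter, so neither compound can be called the stronger one. Compound 3, `Cc1ccc(C(=O)NCCNc2nccc(-c3c(-c4cccc(F)c4)nc4sccn34)n2)cc1`, differs from compound 2 by (4-methylphenyl)carbonyl in place of phenylsulfonyl on an amine nitrogen. Among the compounds with values here, no measured step touches the sulfonyl or carbonyl part of the linker; the only known step concerns a chloro group elsewhere. The expected change no change at the digits printed from compound 2 to compound 3 (within the scatter) is therefore none beyond the scatter. Compound 3 is estimated at 11000 nM, within 3500 nM to 35000 nM.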

Compound 3, half-maximal inhibitory concentration: 5880 nM
The estimate for compound 3 lay 1.9-fold (0.27 log units) above the measured number, and the stated range covers the measured number.
By their numbers in this assay, from the lowest: compounds 3, 2 and 1 (each within the scatter of the next, the first and the last beyond it).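

In this assay, within the data shown here, the amine nitrogen of the linker accepts a (4-methylphenyl)carbonyl group in place of a sulfonyl group: the change gives a 1.9-fold lower number from compound 2 to compound 3 (0.27 log units; within the scatter) and so no clear gain, while the exchange for (4-chlorophenyl)sulfonyl gives a 3.2-fold lower number from compound 1 to compound 3 (0.50 log units; beyond the scatter) and is the only step here beyond the scatter. No supporting data explain this result. From the compounds shown here alone, both steps change the linking group and the ring substituent at once, so their separate contributions remain open. A plain benzoyl group on the same nitrogen would separate the two.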